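The compounds below may be only part of what the source reports. "The series", "measured", "known", "first", "only" and "open" are said of these compounds alone.

Three compounds share one core. Compound 1 `O=C(Nc1ccc(Oc2cc(O)ncn2)cc1)Nc1cccc(C(F)(F)F)c1` carries a hydroxy group on that core and, in an assay on isolated protein for inhibition of serine/threonine-protein kinase TNNI3K (Homo sapiens) (on this read-out lower numbers stand for stronger inhibition and higher numbers for weaker inhibition), gives 3200 nM, the highest number of the three. Compound 2 `CNc1cc(Oc2cc(C)c(NC(=O)Nc3cccc(C(F)(F)F)c3)cc2C)ncn1` gives 32 nM and compound 3 `CCc1cccc(NC(=O)Nc2ccc(Oc3cc(NC)ncn3)cc2)c1` gives 200 nM; both gaps to compound 1 lie beyond the usual scatter, and both of these compounds carry a methylamino group where compound 1 carries hydroxy. Compound 4 `O=C(Nc1ccc(Oc2cc(NCCO)ncn2)cc1)Nc1cccc(C(F)(F)F)c1` differs from compound 1 in one place: (2-hydroxyethyl)amino in place of hydroxy on an aromatic carbon. A step to a lower number is expected from compound 1 to compound 4, of the size a 9.1-fold lower number from compound 1 to compound 4 (0.96 log units; beyond the scatter), because compound 3 with a related amino group gives 200 nM. Compound 4 is therefore estimated at 350 nM, within 100 nM to 1200 nM.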

Compound 4, half-maximal inhibitory concentration: 32 nM
Compound 4: the middle estimate sits 11-fold (1.04 log units) above what was measured, and the stated range ends above it.
By their numbers in this assay, from the lowest: compounds 2 and 4 (each within the scatter of the next); then compound 3; then compound 1.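

In this assay, the change at this one aromatic carbon gives a large step, a 100-fold lower number from compound 1 to compound 4 (2.00 log units; beyond the scatter), with (2-hydroxyethyl)amino in place of hydroxy. Unlike the earlier compounds, which differ from compound 1 in more than one place, this pair isolates the position and shows that the number depends strongly on the group sitting there. Nothing shown accounts for the size of this step.
Still open, going by these compounds, is how much of the step depends on the chain's terminal hydroxy rather than its amino link. An ethylamino group or a longer chain ending in a carboxylic acid would test this.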